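The source may hold more compounds than are shown below. What is called first, only, known or untested is meant among the compounds shown, and "the series" means these compounds.

Measured compounds:
- Compound 1, `O=C(CSC(=S)N[C@H]1CCOC1=O)Nc1ccc(Cl)cc1`: 50300 nM
- Compound 2, `O=C(CSC(=S)N[C@H]1CCOC1=O)Nc1cccc([N+](=O)[O-])c1`: 5460 nM

Both compounds were tested in a functional assay on MCF7 cells (Homo sapiens) for cytotoxicity, read by MTT assay, with a stated time of 72 h; on this read-out lower numbers stand for stronger inhibition and higher numbers for weaker inhibition. Compound 1 gives the highest of the two numbers, so among the two it is the weaker inhibitor of cell growth. Compound 2 gives the lower number, and the gap between compound 1 and compound 2 is beyond the usual scatter of repeated measurements.

Compound 3, `CCCCc1ccc(NC(=O)CSC(=S)N[C@H]2CCOC2=O)cc1`, has not yet been measured. Relative to compound 1 it carries one change: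
butyl in place of chloro on an aromatic carbon

Among the measured compounds shown here, no step between two measured compounds matches this change, so nothing here shows how butyl in place of chloro affects the read-out. The expectation is therefore a step of a 1.3-fold lower number from compound 1 to compound 3 (0.10 log units; within the scatter) in this assay, meaning no change that can be told from the scatter. Compound 3 is estimated at 40000 nM, within a range from 12000 nM to 130000 nM.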

Compound 3, half-maximal inhibitory concentration: 40200 nM
Estimate against measurement, compound 3: 1.0-fold (0.00 log units) below, within the range that was stated.
By their numbers in this assay, from the lowest: compound 2; then compounds 3 and 1 (each within the scatter of the next).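

In this assay, among the compounds shown here, putting butyl in place of chloro, on an aromatic carbon para to a large group, gives a 1.3-fold lower number from compound 1 to compound 3 (0.10 log units; within the scatter), a first direct reading for this position. The substituent here grows from 1 heavy atom, a chlorine, to 4 heavy atoms, all carbon, yet the two compounds cannot be told apart, so this position takes the larger chain with no measurable difference in the read-out. Nothing measured on these compounds explains this result.

Still open, from the compounds shown here alone, is whether an amine, a carboxylic acid or a chain longer than butyl at this same position would give a clearly different number. Also open, going by these compounds, is whether, in this assay, butyl would read the same on another carbon of the ring.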